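From Bromine to Methoxy on the Sulfur-Linked Benzyl Arm

The compounds below may be only part of what the source reports. "The series", "measured", "known", "first", "only" and "open" are said of these compounds alone.

Compound 1 `Cc1cc(Nc2ccn(Cc3cccc4ccccc34)n2)n2nc(SCc3ccc(Br)cc3)nc2n1` gives 5660 nM in a functional assay on PC-9 cells (Homo sapiens) for inhibition, read by MTT assay, with a stated time of 72 h; a lower number here means a stronger inhibitor, a higher number a weaker inhibitor.
Compound 2 `Cc1cc(Nc2cc(-c3ccccc3)[nH]n2)n2nc(SCc3ccc(F)cc3)nc2n1` gives 8110 nM in this assay.
Compound 3 `Cc1cc(Nc2cc(-c3ccccc3)[nH]n2)n2nc(SCc3ccccc3Br)nc2n1` gives 5630 nM in this assay.

Three compounds share one core and differ only in the substituted benzyl group attached through sulfur. Compound 3 has the lowest of the three numbers, but its gap to compound 1 is nil and its gap to compound 2 is within the scatter, so the three are best read as equally weak inhibitors. Going by the values given here, the one step between neighbours, a 1.4-fold lower number from compound 2 to compound 3 (0.16 log units; within the scatter), shows that moving from 4-fluorophenyl to 2-bromophenyl on the saturated chain carbon bound to sulfur changed nothing that the measurement can resolve.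

Compound 4 `COc1ccc(CSc2nc3nc(C)cc(Nc4cc(-c5ccccc5)[nH]n4)n3n2)cc1` carries the next variation: 4-methoxyphenyl in place of 2-bromophenyl on a saturated chain carbon bound to a sulfur. Among the compounds with values here, no measured pair covers a methoxy group at this position, and no pair covers a move from an ortho- to a para-substituted ring alone, so the only guide is that the single comparable step, a 1.4-fold lower number from compound 2 to compound 3 (0.16 log units; within the scatter), stayed flat. The expectation is therefore a step of a 1.1-fold higher number from compound 3 to compound 4 (0.03 log units; within the scatter), that is, no change beyond the scatter. Compound 4 is estimated at 6000 nM, with a plausible range from 2500 nM to 15000 nM.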

Compound 4, half-maximal inhibitory concentration: 8110 nM
Beside the measured number, compound 4's estimate is 1.4-fold (0.13 log units) below it; the measured number falls inside the stated range.
By their numbers in this assay, from the lowest: compounds 3, 1, 2 and 4 (each within the scatter of the next).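

Swapping 2-bromophenyl for 4-methoxyphenyl on the saturated chain carbon bound to a sulfur brings in one hydrogen-bond acceptor where there was none, yet this assay records a 1.4-fold higher number from compound 3 to compound 4 (0.16 log units; within the scatter) as the outcome. The tighter comparison is methoxy in place of fluoro on an aromatic carbon, a change of one group alone, and it gives no change at the digits printed from compound 2 to compound 4 (within the scatter) as its result, so compound 2, compound 3 and compound 4 now show three different substituted rings on this arm with no difference the measurement can resolve. No measurement is available to explain this flatness.

The compounds shown leave open whether a group of another kind on this ring, such as an amine or a carboxylic acid, or a longer chain between the sulfur and the ring, would move the number beyond the scatter. They also leave open whether changes to this arm would stay as flat with the other substituent that compound 1 carries on the shared core.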